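Small ring change on a low-clearance compound

The compounds below may be only part of what the source reports. "The series", "measured", "known", "first", "only" and "open" are said of these compounds alone.

Compound 1 `O[C@H](c1ccccn1)[C@]1(c2cccc(OC(F)(F)F)c2)C[C@H](O)C1`: 117 mL/min/kg
Compound 2 `O[C@H](c1ccccn1)C1(c2ccc(Cl)c(Cl)c2)CC(F)(F)C1`: 850 mL/min/kg
Compound 3 `C[C@]1(O)C[C@](c2ccnc(C(F)(F)F)c2)([C@H](O)c2ccccn2)C1`: 83.3 mL/min/kg

All three numbers come from one test (an ADME assay on liver for metabolic stability, with Liver microsome (Rattus norvegicus) as the target, read by LC-MS, using microsomes, with a stated time of 5 h; on this read-out lower numbers stand for slow clearance and higher numbers for fast clearance). Repeat measurements in such a test naturally differ somewhat, so close numbers cannot be told apart. Compound 3 (83.3 mL/min/kg) and compound 1 (117 mL/min/kg) lie within that scatter of each other. Compound 2 (850 mL/min/kg) lies far beyond the scatter from compound 3.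

Compound 4 `O[C@H](c1ccccn1)[C@]1(c2ccnc(C(F)(F)F)c2)C[C@H](O)C1` differs from compound 3 in one place: hydrogen in place of methyl on a saturated ring carbon. Among the compounds with values here, no measured pair shows this change alone, so the evidence is indirect. Compound 1 also carries hydrogen on that ring carbon, and its number (117 mL/min/kg) lies within the scatter of compound 3, though its aromatic group is different. A small step, within the scatter, is therefore expected (a 1.1-fold lower number from compound 3 to compound 4 (0.05 log units; within the scatter)). For compound 4 the estimated clearance is 75 mL/min/kg (range 32 mL/min/kg to 170 mL/min/kg).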

Compound 4, clearance: 50 mL/min/kg
For compound 4 the middle estimate is 1.5-fold (0.18 log units) above the measured one; low and high end bracket the measured number.
By their numbers in this assay, from the lowest: compounds 4, 3 and 1 (each within the scatter of the next, the first and the last beyond it); then compound 2.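

Within the data shown here, this pair in this assay is the first to show this change alone, with the rest of the molecule the same. The step is a 1.7-fold lower number from compound 3 to compound 4 (0.22 log units; within the scatter), so on this saturated ring carbon of a four-membered non-aromatic ring of carbon only, methyl can give way to hydrogen without a shift in clearance that stands out from the scatter. Nothing in the data shown explains the size of this step.

The compounds shown compare only methyl and hydrogen at this position, so an ethyl group, a fluorine atom or a methoxy group there could give quite a different number. As far as these compounds go, it also remains open whether the same change would give a similar step with the aromatic group of compound 1 or compound 2.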